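The source may report more compounds than this note shows. Statements on the series, on what has been measured and on what is new or still open speak of the compounds shown alone.

In an ADME assay on WI-38 cells (Homo sapiens) for cytotoxicity, read by MTT assay, with a stated time of 72 h (on this read-out lower numbers stand for stronger inhibition and higher numbers for weaker inhibition), compound 1 (`C#Cc1cccc(NC(=O)CCc2cccc3c2B(O)OC3)c1`) shows > 100000 nM as a limit only. Compound 2 (`O=C(CCc1cccc2c1B(O)OC2)Nc1cccc(-c2cccc(F)c2)c1`) gives 37000 nM and the step of an at least 2.7-fold lower number from compound 1 to compound 2 (0.43 log units; beyond the scatter) puts 3-fluorophenyl in place of ethynyl on an aromatic carbon. Compound 3 (`O=C(CCc1cccc2c1B(O)OC2)Nc1cccc(-c2ccc(OC(F)(F)F)cc2)c1`) gives 25000 nM and lies within the scatter of compound 2. Compound 4 (`N#Cc1ccc(-c2cccc(NC(=O)CCc3cccc4c3B(O)OC4)c2)cc1`) differs from compound 3 by cyano in place of trifluoromethoxy on an aromatic carbon and so carries cyano in place of trifluoromethoxy on an aromatic carbon, para to a large group. Going by the values given here, the one measured step concerns another group and sets no size for this change. Compound 3 at 25000 nM stays within the scatter of compound 2 at 37000 nM despite their different substituents, so no step beyond the scatter is expected. The estimated step is a 1.4-fold higher number from compound 3 to compound 4 (0.15 log units; within the scatter) in this assay and stays within the scatter. Compound 4 is estimated at 35000 nM with a range from 17000 nM to 75000 nM as its expected span.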

Compound 4, half-maximal inhibitory concentration: 12000 nM
The estimate for compound 4 lay 2.9-fold (0.46 log units) above the measured number; measured number below the stated range.
By their numbers in this assay, from the lowest: compound 4; then compounds 3 and 2 (each within the scatter of the next). At a limit, above all of these: compound 1.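

In this assay, the step of a 2.1-fold lower number from compound 3 to compound 4 (0.32 log units; beyond the scatter) shows that a change on this aromatic carbon, para to a large group, can move the number beyond the scatter, with cyano as the entering group. The 4-cyanophenyl group also separates from 3-fluorophenyl, with a 3.1-fold lower number from compound 2 to compound 4 (0.49 log units; beyond the scatter). Against ethynyl there is an at least 8.3-fold lower number from compound 1 to compound 4 (0.92 log units; beyond the scatter), a bound only, as its starting value is a limit: the limit of > 100000 nM in this assay, at which 1 of the 4 values shown sits.

Going by these compounds, what an amine or a carboxylic acid at this place would give stays open, and so does whether the cyano step carries over to another core.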